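Amide-linked diacid series: carboxy for nitro

A few compounds are considered here, and "the series" means these few. Any claim that something is new, unique, unknown or untested is made for them only; others in the source may bear on it.

Measured compounds in a functional assay on the whole organism with Rattus norvegicus as the target, at a dose of 25 mg/kg by the intravenous route; on this read-out higher numbers stand for an effect only at larger amounts of compound and lower numbers for an effect already at smaller amounts:
compound 1 `O=C(Nc1ccc(-c2nn[nH]n2)cc1)c1cccc(-c2nn[nH]n2)c1` gives 0.05 mg/kg
compound 2 `O=C(O)c1cc(NC(=O)c2ccc([N+](=O)[O-])cc2)cc(C(=O)O)c1` gives 9.8 mg/kg
compound 3 `N#Cc1cccc(C(=O)Nc2cc(C(=O)O)cc(C(=O)O)c2)c1` gives 5 mg/kg

Compound 2 stands at the highest of the three numbers in this assay. Its nearest neighbour is compound 3, whose number is lower by an amount that falls within the scatter, so no order between compound 2 and compound 3 can be stated. Compound 1, built on a different core, lies furthest away, with a number beyond the scatter lower than that of compound 2.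

Compound 4 `O=C(O)c1ccc(C(=O)Nc2cc(C(=O)O)cc(C(=O)O)c2)cc1` has not yet been measured in this assay. It differs from compound 2 in one place: carboxy in place of nitro on an aromatic carbon. Among the measured compounds shown here, nothing among the measured compounds shows what this exchange does on this core, since no pair of measured compounds differs in exactly this way. The expectation is therefore a step from compound 2 to compound 4 of no size beyond the scatter, in no particular direction: a 1.2-fold lower number from compound 2 to compound 4 (0.09 log units; within the scatter). Compound 4 is expected to give about 8 mg/kg, with a range from 3 mg/kg to 25 mg/kg.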

Compound 4, dose for 50% inhibition: 2.1 mg/kg
Beside the measured number, compound 4's estimate is 3.8-fold (0.58 log units) above it; the whole stated range lies above it.
By their numbers in this assay, from the lowest: compound 1; then compound 4; then compounds 3 and 2 (each within the scatter of the next).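

In this assay, among the compounds shown here, carboxy in place of nitro on an aromatic carbon, para to a large group, gives a 4.7-fold lower number from compound 2 to compound 4 (0.67 log units; beyond the scatter): the first evidence on the shared core that the group at this position affects the read-out, as no earlier pair differed in one place. The step is modest but beyond the scatter, although the two groups have the same heavy-atom count and differ in the counts of hydrogen-bond donors and acceptors. Nothing measured here links the step to any property of either group.

Going by these compounds, it remains open whether an amine or a methyl ester at this position would give a number closer to that of compound 4 or of compound 2. Also open, on these data alone, is whether the same exchange would produce a step of similar size on the core of compound 1.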